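The compounds below may be only part of what the source reports. "The series", "measured", "known", "first", "only" and "open" are said of these compounds alone.

In a physicochemical assay for lipophilicity (a lower number here means a more polar compound, a higher number a more lipophilic compound), compound 2 (`C=CCCOC[n+]1ccn(C)c1/C=N/O`) gives -1.84 and sits within the scatter of compound 1 (`C=C(C)COC[n+]1ccn(C)c1/C=N/O`), which gives -1.83 on the same scale. The two readings cannot be told apart. Compound 3 (`CC#CC(C)OC[n+]1ccn(C)c1/C=N/O`) has no reading yet. Going from compound 2 to compound 3 the change is a group of 5 heavy atoms (5 carbon; no ring) in place of a group of 4 heavy atoms (4 carbon; no ring), on an oxygen on a saturated carbon and it lies on an oxygen on a saturated carbon, where a group with a triple bond takes the place of one with a double bond. Among the measured compounds shown here, only one measured step bears on this: a number 0.01 log units lower from compound 1 to compound 2 (within the scatter) for a swap of one group with a double bond for another. For the measured compounds named here, no measured compound carries a triple bond, and no measured step shows what a larger group does, so the evidence is thin. On that basis the step of a number 0.14 log units higher from compound 2 to compound 3 (within the scatter) is expected to be small and slightly upward, probably within the scatter. For compound 3 the estimated value is -1.7 with an expected range from -2.05 to -1.35 for now.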

Compound 3, distribution coefficient: -1.74
Beside the measured number, compound 3's estimate is 0.04 log units above it, within the range that was stated.
By their numbers in this assay, from the lowest: compounds 2, 1 and 3 (each within the scatter of the next).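

Among the compounds shown here, at this position, on an oxygen on a saturated carbon, the earlier pair showed only one group with a double bond exchanged for another; here a group with a triple bond and 5 heavy atoms enters, and this assay gives a number 0.10 log units higher from compound 2 to compound 3 (within the scatter) and a number 0.09 log units higher from compound 1 to compound 3 (within the scatter). So, among these three compounds, neither the triple bond nor the group of 5 heavy atoms in place of one of 4 carries the reading beyond the usual scatter of repeated measurements, and the three values cannot be put in any order. No supporting measurement is available to explain this result.

The triple bond and the larger size arrive together in one step, so these compounds cannot show what each does alone, and a group of 5 carbon atoms with a double bond would be needed to separate the two. It also remains open whether this assay would stay as flat with a much longer chain, a phenyl ring, an amine or a carboxylic acid in this place, since every group shown here consists of carbon and hydrogen only.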